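The compounds below may be only part of what the source reports. "The series", "measured", "known", "first", "only" and "open" are said of these compounds alone.

Compound 1 `COc1ccc(-c2[nH]c3cc(OC)cc(OC)c3c(=O)c2I)cc1`: in a functional assay on HepG2 cells (Homo sapiens) for antiproliferative activity, with a stated time of 72 h (on this read-out lower numbers stand for an effect already at smaller amounts and higher numbers for an effect only at larger amounts of compound), compound 1 gives > 86200 nM, a limit of the assay.
Compound 2 `COc1ccc(-c2c(I)c(=O)c3c(OC)cc(OC)cc3n2S(=O)(=O)c2ccc(OC)cc2)cc1`: in this assay compound 2 gives > 17300 nM, a limit.
Compound 3 `COc1ccc(-c2cc(=O)c3c(OC)cc(OC)cc3n2S(=O)(=O)c2ccc(C=O)cc2)cc1`: in this assay compound 3 gives > 34400 nM, a limit.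

Compound 3 thus stands only at a limit (the limit of > 34400 nM in this assay, at which 1 of the 3 values shown sits), and no number is known for it. Among the measured compounds shown here, the one single-point step, a step that the two limits leave unreadable from compound 1 to compound 2, runs between two limits and cannot be read. Compound 4 `COc1ccc(-c2cc(=O)c3c(OC)cc(OC)cc3n2S(=O)(=O)c2ccc(C)cc2)cc1` differs from compound 3 by methyl in place of formyl on an aromatic carbon. For the measured compounds named here, no measured step touches this change, so nothing here points to a shift beyond the usual scatter in either direction. Compound 4 is therefore expected to remain near the limit, with the estimated step that the limit leaves unreadable from compound 3 to compound 4. The estimate for compound 4 is 40000 nM, between 15000 nM and 100000 nM.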

Compound 4, half-maximal effective concentration: > 44800 nM
Compound 4: only a limit was reported; the forecaster's own chance of this, stated with the estimate: 80%; middle value at least 1.1-fold (0.04 log units) from the limit.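

Among the compounds shown here, compound 3 and compound 4 both stand only at limits, so the swap of formyl for methyl gives no step that can be read. The compounds shown leave open at what amount, if any, each one takes effect in this assay.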